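Swapping a Chlorinated Ring for a Methoxy-Bearing One

A few compounds are considered here, and "the series" means these few. Any claim that something is new, unique, unknown or untested is made for them only; others in the source may bear on it.

Of the compounds shown here, two have been measured in a functional assay on HT-29 cells (Homo sapiens) for cytotoxicity, read by MTT assay, with a stated time of 72 h; a lower number here means a stronger inhibitor, a higher number a weaker inhibitor. Compound 2 `Cc1c(/N=C/c2ccccc2Cl)c(=O)n(-c2ccccc2)n1C` gives 309000000 nM. Compound 1 `CCOc1cccc(/C=N/c2c(C)n(C)n(-c3ccccc3)c2=O)c1` gives 295000000 nM, and the two numbers sit within the usual scatter of each other, so neither can be called the stronger or the weaker inhibitor; both are very weak. Compound 3 `COc1cccc(/C=N/c2c(C)n(C)n(-c3ccccc3)c2=O)c1` is a new compound made from compound 2 by one change: 3-methoxyphenyl in place of 2-chlorophenyl on a carbon with a double bond to nitrogen. Going by the values given here, no pair of measured compounds differing only at this spot exists to set the size of such a step. Compound 1 and compound 2 both carry a substituted aromatic ring at the same point and give numbers within scatter, so the expected step from compound 2 to compound 3 in this assay is a 1.0-fold lower number from compound 2 to compound 3 (0.01 log units; within the scatter), essentially none beyond the scatter. Compound 3 is therefore expected to give about 300000000 nM, in a range from 150000000 nM to 600000000 nM.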

Compound 3, half-maximal inhibitory concentration: 155000000 nM
Estimate against measurement, compound 3: 1.9-fold (0.29 log units) above; measured number inside the range.
By their numbers in this assay, from the lowest: compounds 3, 1 and 2 (each within the scatter of the next).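

Both new steps give this position its first direct readings in this assay. Placing 3-methoxyphenyl in place of 2-chlorophenyl on the carbon with a double bond to nitrogen gives a 2.0-fold lower number from compound 2 to compound 3 (0.30 log units; within the scatter) and so cannot be told apart from no change. Putting hydrogen in place of methyl on the saturated chain carbon bound to an oxygen on the aromatic ring gives a 1.9-fold lower number from compound 1 to compound 3 (0.28 log units; within the scatter) and likewise leaves compound 3 within the scatter of compound 1, so all three compounds remain very weak.

Going by these compounds, whether an amine or a carboxylic acid on that aromatic ring would shift the number beyond the scatter remains open. Nothing available bears on what lies behind these numbers.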